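Swapping a benzyl for a 4-chlorophenyl on a shared core

The source may hold more compounds than are shown below. What is called first, only, known or untested is meant among the compounds shown, and "the series" means these compounds.

Measured so far:
- compound 1 `C=C(Br)C(=O)Nc1cccc(-c2cn3nc(Cc4ccccc4)sc3n2)c1`: 4500 nM
- compound 2 `COc1ccc(-c2nn3cc(-c4cccc(N)c4)nc3s2)cc1`: >= 250000 nM

Of the compounds shown here, two have been measured in a functional assay on HeLa cells (Homo sapiens) for inhibition, read by cell counting, with a stated time of 4 days; on this read-out higher numbers stand for weaker inhibition and lower numbers for stronger inhibition. Compound 1 gives 4500 nM, the only plain number shown. For compound 2 the result is a limit of the assay, not a number: compound 2 gives >= 250000 nM, and the limit of >= 250000 nM in this assay, at which 1 of the 2 values shown sits, marks where it sits. Going by the values given here, compound 1 therefore stands alone as the single measured point; no step between two measured compounds is known, so there is no measured guide to how large a change on the core moves the read-out.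

Compound 3 `C=C(Br)C(=O)Nc1cccc(-c2cn3nc(-c4ccc(Cl)cc4)sc3n2)c1` is not yet measured. It keeps everything in compound 1 except one substituent: 4-chlorophenyl in place of benzyl on an aromatic carbon. Both groups carry no hydrogen-bond donors or acceptors and no charge.

Among the compounds with values here, with no measured step to lean on, the expectation is for compound 3 to stay close to compound 1, within the usual scatter or a little beyond it in either direction. The estimated step from compound 1 to compound 3 is a 1.1-fold higher number from compound 1 to compound 3 (0.05 log units; within the scatter). Compound 3 is expected to give about 5000 nM in this assay, plausibly between 1500 nM and 20000 nM.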

Compound 3, half-maximal inhibitory concentration: 3000 nM
Compound 3: the middle estimate sits 1.7-fold (0.22 log units) above what was measured; the measured number falls inside the stated range.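

In this assay this position now has a measured step: a 1.5-fold lower number from compound 1 to compound 3 (0.18 log units; within the scatter). On this aromatic carbon, next to the ring nitrogen and next to the ring sulfur, 4-chlorophenyl can therefore stand in place of benzyl with no change beyond the usual scatter of repeat measurements, so this swap gives no sign that the read-out depends on which of the two groups is present. Neither group carries a hydrogen-bond donor, a hydrogen-bond acceptor or a charge, and nothing measured here bears on why the two read alike.

Going by these compounds, a single step covers only these two groups, so it remains open whether the same position would accept an amine, a carboxylic acid, a plain phenyl or a longer chain, and whether the chlorine on the ring contributes anything. Also open is what the bromine-bearing amide on the other side of the shared core contributes, as no pair of compounds shown differs only in that part.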